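This account rests on a few compounds, and the source may have more. Where it says the series, first, only, none or still open, it means among the compounds named here.

Among the measured compounds shown here, compound 3, `O=C(N[C@H]1CN(S(=O)(=O)c2ccccc2)C[C@@H]1C(=O)N[C@H]1CCCNC1)c1cc(-c2ccccc2)on1`, is the one measured compound that yields a number in an ADME assay on cells (Hepatocyte, Rattus norvegicus) for metabolic stability; a higher number here means faster removal of the compound, a lower number slower removal: compound 3 gives 6.8 uL/min. Compound 1, `O=C(N[C@H]1CN(S(=O)(=O)c2ccccc2)C[C@@H]1C(=O)N[C@H]1CCCNC1)c1cc(C2CC2)n[nH]1`, gives a result that is a limit of this assay, < 1 uL/min. Compound 2, `O=C(N[C@H]1CN(S(=O)(=O)c2ccccc2)C[C@@H]1C(=O)N[C@H]1CCCNC1)c1cn(C2CC2)cn1`, likewise gives a limit, < 1 uL/min. Both sit at the limit of < 1 uL/min in this assay, at which 2 of the 3 values shown sit, so compound 3 stands as the fastest-cleared of the three, by an at least 6.8-fold higher number from compound 1 to compound 3 (0.83 log units; beyond the scatter) and an at least 6.8-fold higher number from compound 2 to compound 3 (0.83 log units; beyond the scatter). Compound 4, `O=C(N[C@H]1CN(S(=O)(=O)c2ccccc2)C[C@@H]1C(=O)N[C@H]1CCCNC1)c1cc(-c2ccccc2Cl)on1`, differs from compound 3 by chloro in place of hydrogen on an aromatic carbon. For the measured compounds named here, no measured step touches this part of the molecule; all three measured steps swap the heterocycle on the carbonyl carbon, so no step beyond the scatter is expected from it. Compound 4 is therefore estimated at 8 uL/min, in the range 3 uL/min to 20 uL/min. That estimate means a step of a 1.2-fold higher number from compound 3 to compound 4 (0.07 log units; within the scatter).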

Compound 4, intrinsic clearance in a liver preparation (reported as CLH), per the amount of preparation that the assay uses: 8.3 uL/min
For compound 4 the middle estimate is 1.0-fold (0.02 log units) below the measured one; the range from low to high includes it.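

This is the one change shown on the phenyl ring, and it opens the first look at this position: in this assay, chloro on an aromatic carbon, ortho to a large group, gives a 1.2-fold higher number from compound 3 to compound 4 (0.09 log units; within the scatter), so the step does not separate the two compounds. The gap to the cyclopropyl-bearing heterocycles remains, with an at least 8.3-fold higher number from compound 2 to compound 4 (0.91 log units; beyond the scatter) and an at least 8.3-fold higher number from compound 1 to compound 4 (0.91 log units; beyond the scatter). Both of these steps start from a limit, not a number: the limit of < 1 uL/min in this assay, at which 2 of the 4 values shown sit.

Going by these compounds, whether an amine or a methoxy group on this phenyl ring, or chloro on another of its carbons, would give a step beyond the scatter stays open.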